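Diacetylation of an amine already at the assay limit

A few compounds are considered here, and "the series" means these few. Any claim that something is new, unique, unknown or untested is made for them only; others in the source may bear on it.

In a functional assay on A549 cells (Homo sapiens) for cytotoxicity, read by MTT assay, with a stated time of 48 h (a higher number here means a weaker inhibitor, a lower number a stronger inhibitor), compound 1 `COc1ccc(-c2c(-c3cc(OC)c(OC)c(OC)c3)noc2N)cc1` gives 4490 nM as its half-maximal inhibitory concentration. Compound 2 `COc1ccc(-c2c(-c3cc(OC)c(OC)c(OC)c3)noc2N)cc1OC` gives > 50000 nM which is a limit and not a number, and it stands at the limit of > 50000 nM in this assay, at which 1 of the 3 values shown sits, here. Methoxy in place of hydrogen on an aromatic carbon accounts for the structural difference in an at least 11-fold higher number from compound 1 to compound 2 (1.04 log units; beyond the scatter) as a large step. Compound 3 `COc1ccc(-c2c(-c3cc(OC)c(OC)c(OC)c3)noc2NC(C)=O)cc1` gives 10700 nM with acetyl in place of hydrogen on a nitrogen. That modest step is a 2.4-fold higher number from compound 1 to compound 3 (0.38 log units; beyond the scatter) and it is the nearest guide. Compound 4 `COc1ccc(-c2c(-c3cc(OC)c(OC)c(OC)c3)noc2N(C(C)=O)C(C)=O)cc1OC` has diacetylamino in place of amino on an aromatic carbon and no recovery is expected from it. The expected step is a number no higher from compound 2 to compound 4 (the limit leaves the size open) in this estimate. In this assay compound 4 is estimated at 50000 nM within 15000 nM to 100000 nM and may again read only as a limit.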

Compound 4, half-maximal inhibitory concentration: > 50000 nM
Compound 4 gave a limit, no number; the forecaster's own chance of this, stated with the estimate: 65%; the middle value sits exactly at the limit.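

Compound 2 and compound 4 both read only as limits, so no step between them can be read: the limit of > 50000 nM in this assay, at which 2 of the 4 values shown sit.

The compounds shown leave open whether diacetylamino in place of amino changes the cytotoxicity read-out at all.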